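Swapping the Amide Aryl Group of Compound 1

The compounds below may be only part of what the source reports. "The series", "measured", "known", "first", "only" and "open" are said of these compounds alone.

Among the compounds with values here, compound 1 `CO[C@H]1CC[C@H](NC(=O)c2n[nH]cc2NC(=O)c2cc3ccccn3n2)CC1` is the only compound here with an actual number: in an ADME assay on MRC5 cells (Homo sapiens) for inhibition, with a stated time of 72 h (a higher number here means that more compound is needed for the effect, a lower number that less compound is needed), compound 1 gives 1000 nM. Compound 2 `COc1cccc(OC)c1C(=O)Nc1c[nH]nc1C(=O)O` reaches only a limit of the assay, > 50000 nM. Compound 3 `COc1cccc(OC)c1C(=O)Nc1c[nH]nc1C(=O)NCc1ccccn1` likewise gives only a limit, > 50000 nM. Within the data shown here, the single measured step, a step that the two limits leave unreadable from compound 2 to compound 3, cannot be read because the limit of > 50000 nM in this assay, at which 2 of the 3 values shown sit, holds both of its ends. Compound 4 `CO[C@H]1CC[C@H](NC(=O)c2n[nH]cc2NC(=O)c2cc(Cl)cc(Cl)c2)CC1` differs from compound 1 in one place: a group of 8 heavy atoms (6 carbon, 2 chlorine; one six-membered aromatic ring of carbon only) in place of a group of 9 heavy atoms (7 carbon, 2 nitrogen; one five-membered aromatic ring with 2 hetero atoms, one six-membered aromatic ring with 1 hetero atom), on a carbonyl carbon. Among the measured compounds shown here, no measured step touches this change, so nothing fixes its size or direction, and the estimate stays near compound 1 with a wide range. In this assay compound 4 is therefore expected to give about 3000 nM, between 500 nM and 30000 nM. The expected step of a 3.0-fold higher number from compound 1 to compound 4 (0.48 log units; beyond the scatter) is modest.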

Compound 4, half-maximal effective concentration: 13000 nM
Compound 4: the middle estimate sits 4.3-fold (0.64 log units) below what was measured; low and high end bracket the measured number.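

With 3,5-dichlorophenyl on this carbonyl carbon, this assay shows a 13-fold higher number from compound 1 to compound 4 (1.11 log units; beyond the scatter). Within the data shown here, this is the first readable step, and it shows that the group at this position strongly changes how much compound is needed. Nothing shown gives a reason for this step.

On these data alone, it remains open whether the change follows from the two chlorine atoms or from the loss of the two-ring group with its nitrogens. A plain phenyl or a pyridine ring on the same carbonyl carbon would help separate these two readings.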